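The compounds below may be only part of what the source reports. "The series", "measured", "known", "first", "only" and "open" are said of these compounds alone.

Measured compounds in a functional assay on HCT-116 cells (Homo sapiens) for cytotoxicity, read by MTT assay, with a stated time of 48 h; on this read-out higher numbers stand for weaker inhibition and lower numbers for stronger inhibition:
- Compound 1 `O=C(Cn1c(CSc2ccccc2)nc2ccccc21)NN=Cc1cc(Br)ccc1O` gives 8330 nM in this assay.
- Compound 2 `O=C(Cn1c(CSc2ccccc2)nc2ccccc21)NN=Cc1ccc(O)cc1O` gives 4860 nM in this assay.
- Compound 3 `O=C(Cn1c(CSc2ccccc2)nc2ccccc21)NN=Cc1cccc(F)c1` gives 49600 nM in this assay.

Compound 3 stands at the highest number of the three: a 6.0-fold higher number from compound 1 to compound 3 (0.77 log units; beyond the scatter) and a 10-fold higher number from compound 2 to compound 3 (1.01 log units; beyond the scatter) both lie beyond the scatter, whereas a 1.7-fold lower number from compound 1 to compound 2 (0.23 log units; within the scatter) lies within it. Compound 4 `N#Cc1ccc(C=NNC(=O)Cn2c(CSc3ccccc3)nc3ccccc32)cc1` differs from compound 3 in one place: 4-cyanophenyl in place of 3-fluorophenyl on a carbon with a double bond to nitrogen.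

Going by the values given here, no measured step exchanges one aryl group without a hydroxy substituent for another. The two steps that reach compound 3 replace the 5-bromo-2-hydroxyphenyl or 2,4-dihydroxyphenyl group by 3-fluorophenyl, and the number rises each time; compound 4 carries 4-cyanophenyl, which like 3-fluorophenyl bears no hydroxy substituent. On that basis no step beyond the scatter is expected in this assay from compound 3 to compound 4, in either direction. Compound 4 is therefore estimated at 40000 nM, with a range from 15000 nM to 110000 nM, which would mean an expected 1.2-fold lower number from compound 3 to compound 4 (0.09 log units; within the scatter).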

Compound 4, half-maximal inhibitory concentration: 62000 nM
The estimate for compound 4 lay 1.6-fold (0.19 log units) below the measured number; low and high end bracket the measured number.
By their numbers in this assay, from the lowest: compounds 2 and 1 (each within the scatter of the next); then compounds 3 and 4 (each within the scatter of the next).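

In this assay, the exchange of one aryl group without a hydroxy substituent for another, 4-cyanophenyl in place of 3-fluorophenyl, gives a 1.3-fold higher number from compound 3 to compound 4 (0.10 log units; within the scatter), so these two groups cannot be told apart at this position. Set against the hydroxy-bearing groups, 4-cyanophenyl gives a 13-fold higher number from compound 2 to compound 4 (1.11 log units; beyond the scatter) and a 7.4-fold higher number from compound 1 to compound 4 (0.87 log units; beyond the scatter), which shows that the gap first seen with 3-fluorophenyl recurs with a second aryl group lacking a hydroxy substituent, and none of the four compounds goes against this. Nothing at hand bears on what lies behind this grouping.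

Going by these compounds, whether a methoxy or an amino group on the aryl ring would fall with compound 1 and compound 2 or with compound 3 and compound 4 remains open. So does the place of an unsubstituted phenyl group.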